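Aryl substituent swap on the shared core: methyl for trifluoromethyl

A few compounds are considered here, and "the series" means these few. Any claim that something is new, unique, unknown or untested is made for them only; others in the source may bear on it.

Two compounds of the shared core carry measurements. Compound 1 `CSc1ccccc1-c1nc2ncccc2o1` in a functional assay on the whole organism for inhibition, with Rattus norvegicus as the target, at a dose of 30 mg/kg (on this read-out higher numbers stand for more inhibition at the one dose given (going by the name of the read-out) and lower numbers for less inhibition), gives 21%, and compound 2 `FC(F)(F)c1ccccc1-c1nc2ncccc2o1` in this assay gives 19%. The step of a number 2 percentage points lower from compound 1 to compound 2 (within the scatter) lies within the scatter, so the two numbers cannot be placed in order. Compound 2 stands lowest of the two numbers, with compound 1 nearest and within the scatter of it.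

Compound 3 `Cc1ccccc1-c1nc2ncccc2o1` is not yet measured. Its difference from compound 2 is methyl in place of trifluoromethyl on an aromatic carbon. Within the data shown here, the only measured step, a number 2 percentage points lower from compound 1 to compound 2 (within the scatter), exchanged methylsulfanyl for trifluoromethyl on an aromatic carbon and stayed within the scatter; no measured step involves a methyl group, so nothing bears directly on the change to compound 3. With both measured groups on this aromatic carbon giving numbers within the scatter of each other, no step beyond the scatter is expected in this assay from compound 2 to compound 3. Compound 3 is expected to give 20% in this assay, with a range from 8% to 32%, the expected step being a number 1 percentage points higher from compound 2 to compound 3 (within the scatter).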

Compound 3, a percentage reported as inhibition, in the whole organism at one dose (the size of the read-out at that dose, not a potency): 0%
Compound 3: the middle estimate sits 20 percentage points above what was measured; measured number below the stated range.
By their numbers in this assay, from the lowest: compound 3; then compounds 2 and 1 (each within the scatter of the next).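

In this assay the group on this aromatic carbon makes a difference that the first two compounds could not show: methyl in place of trifluoromethyl gives a number 19 percentage points lower from compound 2 to compound 3 (beyond the scatter) and methyl in place of methylsulfanyl gives a number 21 percentage points lower from compound 1 to compound 3 (beyond the scatter) in the same series. Methylsulfanyl and trifluoromethyl alone left the position looking indifferent to its substituent, since their numbers lie within the scatter of each other, whereas compound 3 shows that the read-out at this dose can be lost through a change at this one carbon, and with the smallest group of the three. Nothing on hand accounts for what separates methyl from the other two groups.

Still open, as far as these compounds go, is whether the drop belongs to methyl alone or would also follow with an ethyl group, a methoxy group or a chlorine atom on the same carbon, and whether an amine or a carboxylic acid there would fall with compound 3 or stay with compound 1 and compound 2. Also open, from the compounds shown here alone, is whether any group on this carbon can lift the number clearly beyond those two compounds in this assay at all.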